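The compounds below may be only part of what the source reports. "The series", "measured", "known", "first", "only" and "open" are said of these compounds alone.

Compound 1, `Cn1c(=O)c(S(=O)(=O)c2ccc(C(=O)O)cc2)cc2cnc(Nc3ccc4[nH]ccc4c3)nc21`, gives 10000 nM in a functional assay on DU-145 cells (Homo sapiens) for inhibition, read by trypan blue exclusion, with a stated time of 72 h; on this read-out higher numbers stand for weaker inhibition and lower numbers for stronger inhibition.
Compound 2, `Cn1c(=O)c(S(=O)(=O)c2ccccc2)cc2cnc(Nc3cnc4[nH]ccc4c3)nc21`, gives 1000 nM in this assay.
Compound 3, `Cn1ccc2cc(Nc3ncc4cc(S(=O)(=O)c5ccc(F)cc5F)c(=O)n(C)c4n3)ccc21`, gives 750 nM in this assay.

Compound 1 stands at the highest number of the three; compound 2 and compound 3 both lie beyond the scatter below it, so compound 1 is the weakest inhibitor here. Compound 4, `Cn1c(=O)c(S(=O)(=O)Nc2ccc(F)cc2F)cc2cnc(Nc3ccc4[nH]ccc4c3)nc21`, differs from compound 1 in one place: (2,4-difluorophenyl)amino in place of 4-carboxyphenyl on a sulfonyl sulfur. Compound 3, which also carries a (2,4-difluorophenyl) ring on its sulfonyl sulfur, shows a lower number than compound 1, but other parts differ too, so no clean step can be read from that pair. The expected step, a 4.0-fold lower number from compound 1 to compound 4 (0.60 log units; beyond the scatter), points toward stronger inhibition. Compound 4 is estimated at about 2500 nM, likely between 600 nM and 10000 nM.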

Compound 4, half-maximal inhibitory concentration: 5000 nM
Beside the measured number, compound 4's estimate is 2.0-fold (0.30 log units) below it; the measured number falls inside the stated range.
By their numbers in this assay, from the lowest: compounds 3 and 2 (each within the scatter of the next); then compounds 4 and 1 (each within the scatter of the next).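

On a sulfonyl sulfur, (2,4-difluorophenyl)amino in place of 4-carboxyphenyl gives a 2.0-fold lower number from compound 1 to compound 4 (0.30 log units; within the scatter) in this assay, so the two compounds cannot be told apart on this read-out. This first one-place comparison shows that swapping these two groups, which differ in their atoms but match in heavy-atom count, leaves no change beyond the scatter. Nothing measured here bears on why the two compounds read alike. Still open, from the compounds shown here alone, is how a group without a ring, such as a simple amine or a short alkyl chain, would read on this sulfonyl sulfur.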